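The source may report more compounds than this note shows. Statements on the series, on what has been measured and on what is new or still open speak of the compounds shown alone.

For the measured compounds named here, in an assay on cells for inhibition of Amine oxidase [flavin-containing] B (Homo sapiens), read by fluorescence, with stated times of 30 min and 15 min (on this read-out lower numbers stand for stronger inhibition and higher numbers for weaker inhibition), compound 1 `CC1(C)C(=O)Nc2ccc(OCc3cccc(Cl)c3)cc21` gives 279000 nM, the highest number among the three compounds measured so far. Compound 2 `CCn1c(=O)[nH]c2ccc(OCCOc3cccc(F)c3)cc21` gives 191000 nM, which lies within the usual scatter of the number for compound 1, so these two cannot be ranked against each other. Compound 3 `O=C1Cc2cc(OCc3ccc(F)cc3)ccc2N1` gives 24900 nM, and its difference from compound 1 goes beyond the scatter. Compound 4 `CC1(C)C(=O)Nc2ccc(OCc3ccc(Cl)c(Cl)c3)cc21` keeps the core of compound 1 and differs from it by chloro in place of hydrogen on an aromatic carbon. Going by the values given here, no measured pair shows this exact change, so any expectation rests on compound 1 alone. The added chloro group is expected to move the number only modestly, toward stronger inhibition, which would mean an estimated step of a 2.0-fold lower number from compound 1 to compound 4 (0.30 log units; within the scatter). Compound 4 is therefore expected to give about 140000 nM, within a range from 50000 nM to 400000 nM.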

Compound 4, half-maximal inhibitory concentration: 132000 nM
The estimate for compound 4 lay 1.1-fold (0.03 log units) above the measured number; measured number inside the range.
By their numbers in this assay, from the lowest: compound 3; then compounds 4, 2 and 1 (each within the scatter of the next, the first and the last beyond it).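

In this assay, placing chloro on the aromatic carbon ortho to a chloro group and para to a large group gives a 2.1-fold lower number from compound 1 to compound 4 (0.33 log units; beyond the scatter), so this position accepts the added chloro with a modest gain in inhibition. For the compounds shown here, this is the first comparison here between compounds that differ in one place, and it rests on a single pair. Nothing available explains the step.

Going by these compounds, whether a methoxy group or an amine on this carbon would move the number further remains open. So does whether chloro would act the same way on the core of compound 3.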